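This account rests on a few compounds, and the source may have more. Where it says the series, first, only, none or still open, it means among the compounds named here.

Measured so far:
- compound 1, `C=C1C(=O)O[C@H]2[C@H]1CC/C(COC(=O)CCC(=O)NCCCCCCNC(=O)Cn1cc(F)c(=O)[nH]c1=O)=C\CC[C@@]1(C)O[C@@H]21`: in a functional assay on Bel-7402 cells (Homo sapiens) for antiproliferative activity, read by MTT assay, with a stated time of 72 h (on this read-out lower numbers stand for stronger inhibition and higher numbers for weaker inhibition), compound 1 gives > 20000 nM
- compound 2, `C=C1C(=O)O[C@H]2[C@H]1CC/C(COC(=O)Cn1cc(F)c(=O)n(Cc3ccc(F)cc3)c1=O)=C\CC[C@@]1(C)O[C@@H]21`: in this assay compound 2 gives 2730 nM

The value for compound 1 is a limit of this assay and not a number (the limit of > 20000 nM in this assay, at which 1 of the 2 values shown sits). Compound 2 is therefore the only one of the two that yields a number in this assay, and nothing has been measured between them that would make a comparison of the two structures meaningful.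

Compound 3, `C=C1C(=O)O[C@H]2[C@H]1CC/C(COC(=O)Cn1cc(F)c(=O)n(Cc3ccc(F)c(F)c3)c1=O)=C\CC[C@@]1(C)O[C@@H]21`, differs from compound 2 in a single place: fluoro in place of hydrogen on an aromatic carbon. Read one bond further out, the change turns a 4-fluorobenzyl group into a 3,4-difluorobenzyl group.

For the measured compounds named here, no measured step between two numbered compounds is available, so the expected size of this change rests on the change itself, which is small. The expectation for compound 3 in this assay is a step of a 1.1-fold lower number from compound 2 to compound 3 (0.04 log units; within the scatter) that stays within the usual scatter of repeated measurements, with no clear direction.

Compound 3 is accordingly estimated at 2500 nM, with a range from 900 nM to 7000 nM.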

Compound 3, half-maximal inhibitory concentration: 2700 nM
Compound 3: the middle estimate sits 1.1-fold (0.03 log units) below what was measured; low and high end bracket the measured number.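

In this assay, the change from 4-fluorobenzyl to 3,4-difluorobenzyl gives a 1.0-fold lower number from compound 2 to compound 3 (0.00 log units; within the scatter). This is the first step between two measured numbers among the compounds shown, and it gives the first direct reading at this aromatic carbon, ortho to a fluoro group: with fluoro in place of hydrogen, the two compounds cannot be told apart in this assay. Nothing in the data shown accounts for this result.

A single fluorine is the only replacement for hydrogen shown at this carbon, so it remains open whether a chlorine, a methoxy group, an amine or a carboxylic acid there would also leave the number within the scatter of compound 2. Compound 1 differs from the other two compounds in more than one place, so no step to it can be read, and the compounds shown do not separate the contributions of its longer chain and of the benzyl groups that compound 2 and compound 3 carry.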